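From 1H-imidazol-1-yl to dimethylamino on the chain

The source may report more compounds than this note shows. Statements on the series, on what has been measured and on what is new or still open speak of the compounds shown alone.

In a functional assay on the whole organism for agonist activity, with Mus musculus as the target (on this read-out lower numbers stand for an effect already at smaller amounts and higher numbers for an effect only at larger amounts of compound), compound 1 (`CC(=O)N(C)CC#CCN(C)C`) gives 1.73 mg/kg and compound 2 (`COC(=O)N(C)CC#CCn1ccnc1`) gives 4.5 mg/kg as the higher of the two numbers, so compound 2 needs the larger dose. Compound 3 (`COC(=O)N(C)CC#CCN(C)C`) has dimethylamino in place of 1H-imidazol-1-yl on a saturated chain carbon bound to a triple-bonded carbon. Within the data shown here, no measured pair shows this change alone. Compound 1 also carries dimethylamino and gives 1.73 mg/kg as its value, so a modest move toward a smaller number is expected in this assay and may only just clear the scatter. The expected step is a 2.3-fold lower number from compound 2 to compound 3 (0.35 log units; beyond the scatter) as an estimate. Compound 3 is expected at 2 mg/kg (estimated range 0.5 mg/kg to 8 mg/kg).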

Compound 3, dose for half-maximal effect: 14.3 mg/kg
Beside the measured number, compound 3's estimate is 7.2-fold (0.85 log units) below it; measured number outside the range, above it.
By their numbers in this assay, from the lowest: compound 1; then compound 2; then compound 3.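

In this assay, dimethylamino in place of 1H-imidazol-1-yl on a saturated chain carbon bound to a triple-bonded carbon raises the dose needed (a 3.2-fold higher number from compound 2 to compound 3 (0.50 log units; beyond the scatter)), so here the aromatic ring of compound 2 is the better of the two groups. The carbonyl carbon is also sensitive: methoxy in place of methyl also raises it (an 8.3-fold higher number from compound 1 to compound 3 (0.92 log units; beyond the scatter)). Nothing measured here gives a cause for either step. Still open, from the compounds shown here alone, is how a piperidine ring would behave on that chain carbon, or an ethoxy group on the carbonyl carbon.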